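The source may report more compounds than this note shows. Statements on the series, on what has been measured and on what is new or still open speak of the compounds shown alone.

Compound 1 `CCOC(=O)N1CCN(Cc2c(O)c([C@H]3CCN(C)C[C@H]3O)c3oc(C)cc(=O)c3c2O)CC1`: 4%
Compound 2 `CN1CC[C@H](c2c(O)cc(O)c3c(=O)cc(/C=C/c4ccccc4)oc23)[C@H](O)C1`: 87%

Both values come from a functional assay on MIA PaCa-2 cells (Homo sapiens) for inhibition, read by MTT assay, with a stated time of 48 h, tested at 10 uM; on this read-out higher numbers stand for more inhibition of growth at the one concentration tested and lower numbers for less inhibition of growth. Compound 2 stands highest of the two at 87%, and compound 1 gives 4%, a gap well beyond the scatter. Compound 3 `CN1CC[C@H](c2c(O)cc(O)c3c(=O)cc(/C=C/c4c(F)c(F)c(F)c(F)c4F)oc23)[C@H](O)C1` is the next compound to be read, and it departs from compound 2 in one place: 2,3,4,5,6-pentafluorophenyl in place of phenyl on a double-bonded chain carbon bound to a double-bonded chain carbon. The fluorines thus replace every hydrogen on the aromatic ring of the phenyl group, while the shared core stays the same. Among the measured compounds shown here, no measured pair shows this exchange, so the expectation is loose. Compound 2 at 87% leaves little room upward in this assay, so a moderate fall is more likely than a rise, and the estimated change is a number 15 percentage points lower from compound 2 to compound 3 (beyond the scatter). For compound 3 the estimated value is 72%, with an expected range of 45% to 94%.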

Compound 3, percent growth inhibition at one concentration: 89%
For compound 3 the middle estimate is 17 percentage points below the measured one; measured number inside the range.
By their numbers in this assay, from the lowest: compound 1; then compounds 2 and 3 (each within the scatter of the next).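

At this place, on a double-bonded chain carbon bound to a double-bonded chain carbon, 2,3,4,5,6-pentafluorophenyl in place of phenyl gives a number 2 percentage points higher from compound 2 to compound 3 (within the scatter) in this assay. The read-out therefore does not separate the two aromatic rings, and replacing every ring hydrogen with fluorine keeps the growth inhibition of compound 2 at the one concentration tested. Nothing measured here bears on the reason for this result.

Still open, on these data alone, is what a single fluorine, a methoxy group or an amine on the phenyl ring would do, and what cyclohexyl in place of phenyl would do. A single concentration also leaves open whether compound 2 and compound 3 would separate at lower concentrations.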